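The source may report more compounds than this note shows. Statements on the series, on what has been measured and on what is new or still open speak of the compounds shown alone.

Compound 2 `C=Cc1ccc(C#Cc2ccc3ncn(-c4ccnc(N)n4)c3c2)cn1` is a close relative of compound 1 `C=CC(=O)NCC#Cc1ccc2ncn(-c3ccnc(N)n3)c2c1`; the two share a core and differ only in the group on a triple-bonded carbon. In an assay on Sf9 cells for inhibition of mitogen-activated protein kinase kinase kinase 14 variant S549D (Homo sapiens), with a stated time of 30 min, in the presence of a further agent that is not named here (on this read-out higher numbers stand for weaker inhibition and lower numbers for stronger inhibition), compound 1 gives 6310 nM, while compound 2 gives 79400 nM. For the measured compounds named here, that single change is the one measured step here: a 13-fold higher number from compound 1 to compound 2 (1.10 log units; beyond the scatter). On the two numbers shown, compound 2 therefore stands at the higher end, the weaker of the pair.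

Compound 3 `C#Cc1cnc(C#Cc2ccc3ncn(-c4ccnc(N)n4)c3c2)nc1` is the next member and has not yet been measured. It differs from compound 2 in one place: a group of 8 heavy atoms (6 carbon, 2 nitrogen; one six-membered aromatic ring with 2 hetero atoms) in place of a group of 8 heavy atoms (7 carbon, 1 nitrogen; one six-membered aromatic ring with 1 hetero atom), on a triple-bonded carbon. The group that enters carries 1 triple bond outside aromatic rings and 2 hydrogen-bond acceptors, the group that leaves 1 double bond outside aromatic rings and 1 hydrogen-bond acceptor.

Going by the values given here, no measured step bears directly on this change. The step from compound 1 to compound 2 exchanged an amide-bearing chain for an aromatic ring and was large, but both compound 2 and compound 3 carry a six-membered aromatic ring at the same position, so that step does not tell how a ring swap of this kind plays out. With nothing to set direction, compound 3 is expected to remain near compound 2, with a step of a 1.3-fold lower number from compound 2 to compound 3 (0.12 log units; within the scatter) that is not expected to exceed the scatter. Compound 3 is accordingly estimated at 60000 nM, within a range from 15000 nM to 200000 nM.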

Compound 3, half-maximal inhibitory concentration: 25100 nM
Compound 3: middle estimate off by 2.4-fold (0.38 log units), on the high side; the range from low to high includes it.
By their numbers in this assay, from the lowest: compound 1; then compound 3; then compound 2.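

In this assay, the aromatic groups on the triple-bonded carbon do not all sit at one level: a 3.2-fold lower number from compound 2 to compound 3 (0.50 log units; beyond the scatter), a modest step beyond the scatter, when 6-vinylpyridin-3-yl gives way to a six-membered aromatic ring with 2 hetero atoms and a triple bond outside the ring. This recovers only part of the earlier loss, since the step of a 13-fold higher number from compound 1 to compound 2 (1.10 log units; beyond the scatter) compares with a 4.0-fold higher number from compound 1 to compound 3 (0.60 log units; beyond the scatter), and compound 1, with its ((vinylcarbonyl)amino)methyl group and no ring, keeps the lowest number of the three. No measurement is available that accounts for this difference between the two ring-bearing groups.

The ring's hetero atoms and the unsaturated bond outside the ring change together between compound 2 and compound 3, so the compounds shown do not separate the contribution of either one. Also open, on these data alone, is how the number would respond if a methyl group or a primary amine stood on the ring in place of that unsaturated carbon chain, or whether a ring-bearing group could match or pass compound 1 at all.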